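Notes on a methyl-to-hydrogen step in the series

A few compounds are considered here, and "the series" means these few. Any claim that something is new, unique, unknown or untested is made for them only; others in the source may bear on it.

Of the compounds shown here, two have been measured so far: compound 1 `COc1cc2c(cc1C)NC(=O)/C2=C/c1c(OC)nc2sc(C)cn12` and compound 2 `COc1nc2sc(C)cn2c1C=C1C(=O)N(C)c2ccccc21`. In a functional assay on cells (Ovarian carcinoma cell, Homo sapiens) for cytotoxicity, read by sulforhodamine B assay, with a stated time of 48 h (on this read-out higher numbers stand for lower toxicity in this test and lower numbers for higher toxicity in this test), compound 1 gives 91400 nM and compound 2 gives 92800 nM. These two numbers lie within the scatter of each other, so compound 1 stands level with compound 2 and neither can be ranked. Among the compounds with values here, no measured pair yet differs in only one place, which leaves the series without a direct reading for any single group.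

The next compound is compound 3 `COc1ccc2c(c1)/C(=C\c1c(OC)nc3sc(C)cn13)C(=O)N2`. It departs from compound 1 in one place: hydrogen in place of methyl on an aromatic carbon, at a carbon ortho to a methoxy group. Within the data shown here, the change is a single heavy atom with no ring and no net charge, and the data offer no precedent for it. No shift beyond the scatter is therefore expected in this assay, and no firm direction can be given. The estimated change is a 1.1-fold lower number from compound 1 to compound 3 (0.06 log units; within the scatter), expected to stay within the scatter. For compound 3 the expected value is 80000 nM, with an estimated range from 35000 nM to 120000 nM.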

Compound 3, concentration lethal to 50% of the cells: 87600 nM
Estimate against measurement, compound 3: 1.1-fold (0.04 log units) below, and the stated range covers the measured number.
By their numbers in this assay, from the lowest: compounds 3, 1 and 2 (each within the scatter of the next).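

Within the data shown here, this is the first one-place step. In this assay, a 1.0-fold lower number from compound 1 to compound 3 (0.02 log units; within the scatter), so hydrogen in place of methyl on this aromatic carbon, ortho to a methoxy group, gives no shift beyond the scatter. The reading holds for this one position on the core of compound 1, and it gives no sign that this methyl group matters in this test, while no measurement of any property of these compounds bears on the result.

The compounds shown leave open whether a different group on the same aromatic carbon, such as a chlorine atom, a trifluoromethyl group or an amine, would keep the number within the scatter of compound 1 and compound 3. They also give no single-place reading for the neighbouring methoxy group itself, so a hydroxyl group or an ethoxy group in its place remains an open question for this series.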